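Removing One Methoxy Group from a Benzimidazole Sulfonamide

The compounds below may be only part of what the source reports. "The series", "measured", "known", "first", "only" and "open" are said of these compounds alone.

Compound 1 `COc1cc(N(Cc2ccccc2)S(=O)(=O)c2ccc(C)cc2)cc(OC)c1OC`: 3570 nM
Compound 2 `COc1cc(N(Cc2nc3ccccc3[nH]2)S(=O)(=O)c2ccc(C)cc2)cc(OC)c1OC`: 1020 nM

Both compounds were examined in a functional assay on MGC-803 cells (Homo sapiens) for inhibition, read by MTT assay, with a stated time of 48 h; a lower number here means a stronger inhibitor, a higher number a weaker inhibitor. Compound 1 gives 3570 nM in this assay, and compound 2 gives 1020 nM. Among the measured compounds shown here, compound 2 therefore stands lowest of the two numbers, the step of a 3.5-fold lower number from compound 1 to compound 2 (0.54 log units; beyond the scatter) separating it from compound 1, which is its only neighbour.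

Compound 3 `COc1ccc(N(Cc2nc3ccccc3[nH]2)S(=O)(=O)c2ccc(C)cc2)cc1OC` is not yet measured. It differs from compound 2 in one place: hydrogen in place of methoxy on an aromatic carbon. For the measured compounds named here, the single measured step, a 3.5-fold lower number from compound 1 to compound 2 (0.54 log units; beyond the scatter), concerns the group on the saturated chain carbon bound to the sulfonamide nitrogen and leaves the ring bearing the methoxy groups untouched, so no measured step bears directly on this change. With nothing in the data to anchor the direction, a modest rise in the number is expected for compound 3, the step being estimated as a 2.5-fold higher number from compound 2 to compound 3 (0.39 log units; beyond the scatter), with a wide range on either side. Compound 3 is thus estimated at 2500 nM in this assay, within a range from 800 nM to 8000 nM.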

Compound 3, half-maximal inhibitory concentration: > 50000 nM
Compound 3 was reported as a limit; the forecaster's own chance of this, stated with the estimate: 5%; middle value at least 20-fold (1.30 log units) from the limit.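

Among the compounds shown here, the step of an at least 49-fold higher number from compound 2 to compound 3 (1.69 log units; beyond the scatter) is the first here to touch the ring bearing the methoxy groups, and it shows that in this assay the number responds far more strongly to this change than to the change on the saturated chain carbon, a 3.5-fold lower number from compound 1 to compound 2 (0.54 log units; beyond the scatter). Compound 3 is reported only as a limit: the limit of > 50000 nM in this assay, at which 1 of the 3 values shown sits. Between these two compounds, the only difference is hydrogen in place of a single methoxy group, ortho to a methoxy group and meta to a large group, so the presence of this methoxy group is enough to separate a compound with a measurable number from one reported only as a limit.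

The compounds shown do not tell whether a group other than methoxy on this aromatic carbon, such as ethoxy, hydroxy, chlorine or an amine, would keep the number close to that of compound 2. They also leave open whether the same replacement would have a comparable effect in compound 1, with phenyl in place of 1H-benzimidazol-2-yl, or at the other two methoxy-bearing carbons.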